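Predicting a para-fluoro anilide from two small steps

The compounds below may be only part of what the source reports. "The series", "measured", "known", "first", "only" and "open" are said of these compounds alone.

Measured so far in a functional assay on HeLa cells (Homo sapiens) for inhibition, read by MTT assay, with a stated time of 48 h; a lower number here means a stronger inhibitor, a higher number a weaker inhibitor:
compound 1, `COc1ccc2c(=O)c(/C=C/C(=O)Nc3ccc(C)cc3)coc2c1`, gives 24100 nM
compound 2, `COc1ccc2c(=O)c(/C=C/C(=O)Nc3ccccc3)coc2c1`, gives > 100000 nM
compound 3, `O=C(/C=C/c1coc2cc(O)ccc2c1=O)Nc1ccccc1`, gives 9700 nM

Compound 2 stands at the weak end of these three numbers. Its result is a limit of the assay rather than a number, which is described by the limit of > 100000 nM in this assay, at which 1 of the 3 values shown sits. Compound 4, `COc1ccc2c(=O)c(/C=C/C(=O)Nc3ccc(F)cc3)coc2c1`, has not yet been measured. It differs from compound 2 in one place: fluoro in place of hydrogen on an aromatic carbon.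

Going by the values given here, two measured steps touch the same region. The step of an at least 4.1-fold higher number from compound 1 to compound 2 (0.61 log units; beyond the scatter) shows that removing a group from that aromatic carbon raised the number at least modestly, so a small group at that carbon appears to help. The step of an at least 10-fold lower number from compound 2 to compound 3 (1.01 log units; beyond the scatter) lies elsewhere on the shared core and does not concern the anilide ring. Fluoro is another small group at the same carbon, so compound 4 is expected to move in the same direction as the methyl compound 1, though with only one such step as guide, and that step starting from a limit, the size is uncertain. Compound 4 is therefore estimated to give 40000 nM, with a plausible range from 12000 nM to 150000 nM, corresponding to an expected step of an at least 2.5-fold lower number from compound 2 to compound 4 (0.39 log units; beyond the scatter).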

Compound 4, half-maximal inhibitory concentration: 9680 nM
The estimate for compound 4 lay 4.1-fold (0.62 log units) above the measured number; measured number outside the range, below it.
By their numbers in this assay, from the lowest: compounds 4 and 3 (each within the scatter of the next); then compound 1. At a limit, above all of these: compound 2.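

In this assay, adding a single fluoro on the aromatic carbon para to a large group turns an anilide beyond the assay's limit into one with a measurable number, a change seen as an at least 10-fold lower number from compound 2 to compound 4 (1.01 log units; beyond the scatter). The full size of this step cannot be stated, because compound 2 sits at a limit of the assay and has no exact number: the limit of > 100000 nM in this assay, at which 1 of the 4 values shown sits. Fluoro and methyl also do not behave alike at this carbon, as the exchange of one for the other gives a 2.5-fold lower number from compound 1 to compound 4 (0.40 log units; beyond the scatter), so the outcome here depends on which group is present and not merely on a group being there.

Going by these compounds, these compounds show only hydrogen, methyl and fluoro at this carbon, so it remains open how a chloro group, a larger group such as trifluoromethyl, or an amine would behave there. On these data alone, it is also open whether the fluoro of compound 4 and the hydroxyl of compound 3, which sit in different places, would add up when carried together on the shared core.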